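This account rests on a few compounds, and the source may have more. Where it says the series, first, only, none or still open, it means among the compounds named here.

Compound 1 `COc1ccc(C(=O)/C=C/c2ccc(F)cc2)c2c1C=CC(C)(C)O2` gives > 10000 nM in a functional assay on SW-620 cells (Homo sapiens) for antiproliferative activity, read by MTT assay, with a stated time of 24 h (on this read-out lower numbers stand for stronger inhibition and higher numbers for weaker inhibition), which is a limit of the assay.
Compound 2 `COc1ccc(C(=O)/C=C/c2cccc(F)c2)c2c1C=CC(C)(C)O2` gives > 10000 nM, also a limit.
Compound 3 `COc1ccc(C(=O)/C=C/c2ccc(Br)cc2)c2c1C=CC(C)(C)O2` gives > 10000 nM, also a limit.

Compound 3 thus stands where the other two measured compounds stand, all three together at the limit of > 10000 nM in this assay, at which 3 of the 3 values shown sit. Compound 4 `COc1ccc(C(=O)/C=C/c2cccc([N+](=O)[O-])c2)c2c1C=CC(C)(C)O2` differs from compound 3 in one place: 3-nitrophenyl in place of 4-bromophenyl on a double-bonded chain carbon bound to a double-bonded chain carbon. The measured steps a step that the two limits leave unreadable from compound 1 to compound 2, a step that the two limits leave unreadable from compound 1 to compound 3 and a step that the two limits leave unreadable from compound 2 to compound 3 are each bounded by two limits and so show no readable size. With every measured value at the limit, no direction for the change to compound 4 can be read. Compound 4 is expected to stay at or near that limit, the step being estimated as a step that the limit leaves unreadable from compound 3 to compound 4. Compound 4 is therefore estimated at 15000 nM, within 3000 nM to 60000 nM.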

Compound 4, half-maximal inhibitory concentration: 4090 nM
Beside the measured number, compound 4's estimate is 3.7-fold (0.56 log units) above it; measured number inside the range.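

Among the compounds shown here, at this position, on a double-bonded chain carbon bound to a double-bonded chain carbon, 3-nitrophenyl gives the only readable number in this assay, with an at least 2.4-fold lower number from compound 3 to compound 4 (0.38 log units; beyond the scatter). The nitro group also stands apart from the fluoro compounds, with an at least 2.4-fold lower number from compound 2 to compound 4 (0.38 log units; beyond the scatter) and an at least 2.4-fold lower number from compound 1 to compound 4 (0.38 log units; beyond the scatter). Compound 4 alone leaves the limit, and the steps among the other three compounds cannot be read: the limit of > 10000 nM in this assay, at which 3 of the 4 values shown sit.

The compounds shown leave open whether 4-nitrophenyl would read like 3-nitrophenyl, and whether an aminophenyl group in this place would also give a number under the limit.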